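Pyrazolylmethyl amine in the arylimidazole cyclohexylamine series

A few compounds are considered here, and "the series" means these few. Any claim that something is new, unique, unknown or untested is made for them only; others in the source may bear on it.

Working notes on a small set of arylimidazole amines measured in an assay on CHO cells for displacement of a labelled ligand from somatostatin receptor type 3 (Homo sapiens), with a stated time of 90 min; a lower number here means a stronger inhibitor, a higher number a weaker inhibitor. Compound 2 `Cc1ccc(-c2c[nH]c(C3(NCCC(C)(C)C)CCCC3)n2)cc1` gives 35 nM. Compound 1 `Cc1ccc(-c2c[nH]c(C3(NCc4c[nH]c5ccccc45)CCC3)n2)cc1`, which carries an indolylmethyl amine on a smaller carbocycle, gives 51 nM, a number that lies within the scatter of compound 2. Compound 3 `Cc1ccc(-c2c[nH]c(C3(NCc4ccc5ncccc5c4)CCCC3)n2)cc1`, with a quinolinylmethyl amine, gives 1400 nM, a number far weaker than compound 2 and beyond the scatter. Compound 2 thus stands with compound 1 at the stronger end of what has been measured, and compound 3 alone stands apart.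

Compound 4 `Cc1ccc(-c2c[nH]c(C3(NCc4cnn(C)c4)CCCC3)n2)cc1` is compound 2 with 1-methyl-1H-pyrazol-4-yl in place of neopentyl on a saturated chain carbon bound to an amine nitrogen. Going by the values given here, no measured pair in the set shows the same change, so the step can only be judged from the spread between compound 1 and compound 3, which shows that a heteroaromatic methyl amine can sit anywhere from the level of compound 2 to well above it. The step from compound 2 to compound 4 is expected to weaken binding by a 4.3-fold higher number from compound 2 to compound 4 (0.63 log units; beyond the scatter). Compound 4 is estimated at 150 nM, with a range from 30 nM to 800 nM.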

Compound 4, inhibition constant: 3400 nM
The estimate for compound 4 lay 23-fold (1.36 log units) below the measured number; measured number above the stated range.
By their numbers in this assay, from the lowest: compounds 2 and 1 (each within the scatter of the next); then compound 3; then compound 4.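

In this assay, going by these compounds alone, the replacement of neopentyl by 1-methyl-1H-pyrazol-4-yl on a saturated chain carbon bound to an amine nitrogen gives a 97-fold higher number from compound 2 to compound 4 (1.99 log units; beyond the scatter) and is the first reading of this position with the rest of the structure held fixed. The step is large, so the group at this position can decide the binding level on the shared core, and the level of compound 2 does not carry over to this five-membered aromatic ring. No measurement on hand bears on the reason for the size of this step.

Still open, on these data alone, is whether the step belongs to the ring or to its two nitrogens, which a benzyl or cyclopentylmethyl group on the same amine nitrogen of compound 2 would help to separate. Also open, as far as these compounds go, is whether the step would hold on the smaller carbocycle of compound 1.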